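The source may report more compounds than this note shows. Statements on the series, on what has been measured and on what is new or still open speak of the compounds shown alone.

Compound 1 `COc1cc(OC)c(-c2coc3cc(OCC(=O)c4cccc(C(F)(F)F)c4)ccc3c2=O)cc1OC`: > 10000 nM
Compound 2 `COc1cc(OC)c(-c2coc3cc(OCc4ccc(C#N)cc4)ccc3c2=O)cc1OC`: 6180 nM

The two compounds were tested in a functional assay on U-251 cells (Homo sapiens) for antiproliferative activity, read by MTT assay, with a stated time of 24 h; on this read-out higher numbers stand for weaker inhibition and lower numbers for stronger inhibition. Compound 1 gives > 10000 nM, which is a limit of the assay and not a number. Among the compounds with values here, compound 2, at 6180 nM, therefore holds the only actual number so far, and it has no measured neighbour to be ranked against.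

The next compound, compound 3 `COc1cc(OC)c(-c2coc3cc(OCc4ccccc4C#N)ccc3c2=O)cc1OC`, keeps the same atoms joined differently: 2-cyanophenyl in place of 4-cyanophenyl on a saturated chain carbon bound to an oxygen on an aromatic ring. In words, 2-cyanophenyl stands in place of 4-cyanophenyl on a saturated chain carbon bound to an oxygen on an aromatic ring.

Within the data shown here, only one measured step is available, an at least 1.6-fold lower number from compound 1 to compound 2 (0.20 log units; that floor lies within the scatter), and it stays within the scatter. Among the measured compounds shown here, that step exchanges a different group, so it bears only loosely on this change, and no measured pair moves the nitrile. With that little to go on, the value of compound 2 remains the best anchor, and no direction can be argued. The expected change is a 1.1-fold higher number from compound 2 to compound 3 (0.02 log units; within the scatter), which means no step beyond the scatter. For compound 3 the estimated value is 6500 nM, with an expected range from 2500 nM to 13000 nM.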

Compound 3, half-maximal inhibitory concentration: 980 nM
Estimate against measurement, compound 3: 6.6-fold (0.82 log units) above; measured number below the stated range.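

In this assay, the same atoms joined differently give a 6.3-fold lower number from compound 2 to compound 3 (0.80 log units; beyond the scatter), the first step among these compounds that rests on two actual numbers, and it shows that where the nitrile sits on this ring matters, even though the counts of atoms, donors and acceptors do not change. Set against the (3-(trifluoromethyl)phenyl)carbonyl group, 2-cyanophenyl gives an at least 10-fold lower number from compound 1 to compound 3 (1.00 log units; beyond the scatter), a step beyond the scatter, whereas 4-cyanophenyl gave only an at least 1.6-fold lower number from compound 1 to compound 2 (0.20 log units; that floor lies within the scatter), whose floor lies within it. Compound 1 carries a limit of the assay and not a number, so that step marks a floor and not a size: the limit of > 10000 nM in this assay, at which 1 of the 3 values shown sits.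

The compounds shown leave open whether 3-cyanophenyl would stand with 2-cyanophenyl or with 4-cyanophenyl, and whether 2-chlorophenyl or 2-methoxyphenyl on the same saturated chain carbon would match the nitrile. They also leave open how a longer chain in place of that single carbon would read out, and they offer no measurement that explains why moving the nitrile changes the number.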